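The compounds below may be only part of what the source reports. "The series", "measured", "known", "first", "only" and "open" are said of these compounds alone.

Compound 1 `Cn1cnc(C(=O)NNC(=O)COc2ccc(C(=O)c3ccccc3)cc2)c1` gives 31900 nM
Compound 2 `Cn1cnc(C(=O)NNC(=O)COc2c(F)cc(C(=O)c3ccc(Cl)cc3)cc2Cl)c1` gives 54500 nM

Both values come from a functional assay on HeLa cells (Homo sapiens) for cytotoxicity, read by LDH release, with a stated time of 48 h (a higher number here means a weaker inhibitor, a lower number a stronger inhibitor), and compound 1 lies within the usual scatter of compound 2. With only these two numbers, compound 1 stands level with the other measured compound.

Compound 3 `O=C(COc1ccc(C(=O)c2ccccc2)cc1)NNC(=O)c1ccc(=O)oc1` keeps the core of compound 1 but changes the ring group on a carbonyl carbon: a group of 7 heavy atoms (5 carbon, 2 oxygen; one six-membered aromatic ring with 1 hetero atom) in place of a group of 6 heavy atoms (4 carbon, 2 nitrogen; one five-membered aromatic ring with 2 hetero atoms), on a carbonyl carbon. Among the measured compounds shown here, no measured pair shows what this change does, so no direction can be favoured and no step beyond the scatter is expected in this assay. The estimated change is a 1.1-fold higher number from compound 1 to compound 3 (0.04 log units; within the scatter). For compound 3 the expected value is 35000 nM, with an estimated range from 14000 nM to 85000 nM.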

Compound 3, half-maximal inhibitory concentration: 96100 nM
For compound 3 the middle estimate is 2.7-fold (0.44 log units) below the measured one; measured number above the stated range.
By their numbers in this assay, from the lowest: compounds 1, 2 and 3 (each within the scatter of the next, the first and the last beyond it).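

Among the compounds shown here, this pair is the first measured comparison that differs in only one place, a ring group on a carbonyl carbon, and so shows that the position is not indifferent to that group. In this assay the six-membered aromatic ring in place of 1-methyl-1H-imidazol-4-yl gives a 3.0-fold higher number from compound 1 to compound 3 (0.48 log units; beyond the scatter) and so a modestly weaker inhibitor. No measurement here accounts for this step.

A single pair cannot show which feature of the new ring matters. Going by these compounds, whether a plain phenyl or a pyridine ring on this carbonyl carbon would restore or improve the value remains open.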